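Series notes: removing the bromo on the benzyl arm

This account rests on a few compounds, and the source may have more. Where it says the series, first, only, none or still open, it means among the compounds named here.

Compound 1 `O=C(CCC1C(=O)N(c2ccc(Cl)cc2)C(=O)N1Cc1ccc(Br)cc1)Nc1ccc(C(=O)NO)cc1` gives 9.7 nM in an assay on isolated protein for inhibition of protein deacetylase HDAC6 (Homo sapiens), read by fluorescence, with stated times of 5 min and 60 min (on this read-out higher numbers stand for weaker inhibition and lower numbers for stronger inhibition), the lowest of the three numbers shown, though each of the other two lies within the scatter of it. Compound 2 `O=C(CCC1C(=O)N(c2ccc(Cl)cc2)C(=O)N1Cc1ccc(Br)cc1)NCc1ccc(C(=O)NO)cc1` gives 16.5 nM in this assay, and compound 3 `Cc1ccc(CN2C(=O)N(c3ccc(Cl)cc3)C(=O)C2CCC(=O)NCc2ccc(C(=O)NO)cc2)cc1` gives 18.9 nM. The step of a 1.7-fold higher number from compound 1 to compound 2 (0.23 log units; within the scatter) is within the scatter, as is a 1.1-fold higher number from compound 2 to compound 3 (0.06 log units; within the scatter). Going by the values given here, compound 1 and compound 3 differ in two places and no single step links them; their two values lie within the scatter of each other.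

Compound 4 `O=C(CCC1C(=O)N(c2ccc(Cl)cc2)C(=O)N1Cc1ccccc1)Nc1ccc(C(=O)NO)cc1` has not yet been measured. It differs from compound 1 by hydrogen in place of bromo on an aromatic carbon; cut one bond further out, the same difference reads 4-bromophenyl to phenyl and 4-bromobenzyl to benzyl. The measured step that bears on this place is a 1.1-fold higher number from compound 2 to compound 3 (0.06 log units; within the scatter), which exchanges the same bromo on the same aromatic carbon for methyl and left the number within the scatter. Among the compounds with values here, no measured step exchanges the bromo for hydrogen, so the two changes are not identical. On that basis only a small step in this assay, if any, is expected for compound 4. The step expected is a 1.5-fold higher number from compound 1 to compound 4 (0.19 log units; within the scatter). Compound 4 is therefore estimated at 15 nM, with a range from 6 nM to 40 nM.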

Compound 4, half-maximal inhibitory concentration: 7.6 nM
Compound 4: middle estimate off by 2.0-fold (0.30 log units), on the high side; the range from low to high includes it.
By their numbers in this assay, from the lowest: compounds 4, 1, 2 and 3 (each within the scatter of the next, the first and the last beyond it).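

In this assay, going by these compounds alone, the change from 4-bromobenzyl to benzyl gives a 1.3-fold lower number from compound 1 to compound 4 (0.11 log units; within the scatter) and so provides the first direct reading of losing the bromo outright, where the earlier step only exchanged it for methyl. With a 1.1-fold higher number from compound 2 to compound 3 (0.06 log units; within the scatter) as the other step at this aromatic carbon, bromo, methyl and hydrogen have now been compared there, and neither step leaves the scatter, although the hydrogen step belongs to the 4-(hydroxycarbamoyl)phenyl series and the methyl step to the 4-(hydroxycarbamoyl)benzyl series. The data therefore show no measurable need for a bromo on the benzyl arm of compound 1, and no measurement in hand offers an explanation for these small steps.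

Still open, going by these compounds, is whether a group of a different kind on this aromatic carbon, such as an amine or a carboxylic acid, would move the number beyond the scatter, and whether the same exchange of bromo for hydrogen would read alike in the 4-(hydroxycarbamoyl)benzyl series. Also unresolved is how a longer chain in place of the benzyl methylene, or a change at the 4-chlorophenyl group, would read in this series.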